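This account rests on a few compounds, and the source may have more. Where it says the series, first, only, none or still open, it means among the compounds named here.

Compound 1 `COc1ccc(CNC(=O)c2cc3cc(OC)c(OCCCOc4no[n+]([O-])c4S(=O)(=O)c4ccccc4)cc3oc2=O)cc1` carries a 4-methoxybenzyl group on its amide-type nitrogen. Within the data shown here, in a functional assay on MCF7 cells (Homo sapiens) for inhibition, read by MTT assay, with a stated time of 48 h (a higher number here means a weaker inhibitor, a lower number a stronger inhibitor), compound 1 gives 560 nM, the second highest of the three numbers measured so far. Compound 2 `COc1cc2cc(C(=O)Nc3ccccc3)c(=O)oc2cc1OCCCOc1no[n+]([O-])c1S(=O)(=O)c1ccccc1`, with phenyl on that nitrogen, gives 740 nM in this assay. Compound 3 `COc1ccc(NC(=O)c2cc3cc(OC)c(OCCCOc4no[n+]([O-])c4S(=O)(=O)c4ccccc4)cc3oc2=O)cc1`, with 4-methoxyphenyl, gives 410 nM. All steps among these three stay small: a 1.3-fold higher number from compound 1 to compound 2 (0.12 log units; within the scatter), a 1.4-fold lower number from compound 1 to compound 3 (0.14 log units; within the scatter), and a 1.8-fold lower number from compound 2 to compound 3 (0.26 log units; within the scatter).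

Compound 4 `COc1cc2cc(C(=O)NCc3ccccc3)c(=O)oc2cc1OCCCOc1no[n+]([O-])c1S(=O)(=O)c1ccccc1` is the unmeasured member. Its difference from compound 1 is hydrogen in place of methoxy on an aromatic carbon, read one bond further out as 4-methoxybenzyl to benzyl. Among the measured compounds shown here, the one measured step that bears on this is the opposite change on the anilide pair, where a 1.8-fold lower number from compound 2 to compound 3 (0.26 log units; within the scatter) covers methoxy in place of hydrogen on an aromatic carbon and stays within the scatter. Removing the methoxy from compound 1 is therefore expected to shift the number little, if at all, perhaps slightly upward. Compound 4 is expected to give about 700 nM in this assay, within a range of 350 nM to 1400 nM. This amounts to an expected step of a 1.3-fold higher number from compound 1 to compound 4 (0.10 log units; within the scatter).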

Compound 4, half-maximal inhibitory concentration: 740 nM
For compound 4 the middle estimate is 1.1-fold (0.02 log units) below the measured one, and the stated range covers the measured number.
By their numbers in this assay, from the lowest: compounds 3, 1, 2 and 4 (each within the scatter of the next).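

Hydrogen in place of methoxy now has a second reading, on the benzyl amides, with a 1.3-fold higher number from compound 1 to compound 4 (0.12 log units; within the scatter). In this assay this change stays within the scatter on both pairs, and the two readings do not differ beyond it: the same change on two cores in this assay, a 1.8-fold lower number (0.26 log units; within the scatter) from compound 2 to compound 3 and a 1.3-fold lower number (0.12 log units; within the scatter) from compound 4 to compound 1, 1.4-fold (0.14 log units) apart, within the scatter of two such steps

The group on the amide-type nitrogen also reads flat with benzyl in the set, with no change at the digits printed from compound 2 to compound 4 (within the scatter) and a 1.8-fold higher number from compound 3 to compound 4 (0.26 log units; within the scatter), so neither benzyl for phenyl nor benzyl for 4-methoxyphenyl goes beyond the scatter.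

The four compounds cover only hydrogen and methoxy at this place, on phenyl or benzyl, so no step beyond the scatter is yet available for this part of the series. From the compounds shown here alone, whether a carboxylic acid or an amine on that aromatic ring, or a longer chain on the amide-type nitrogen, would give such a step remains open.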